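The source may hold more compounds than are shown below. What is called first, only, known or untested is meant among the compounds shown, and "the series" means these compounds.

Measured compounds in the series:

Compound 1, `Cc1ccc2oc(=O)c(-c3ccc(Cl)nn3)cc2c1`: 13500 nM
Compound 2, `Cc1ccc2cc(-c3ccc(Cl)nn3)c(=O)oc2c1`: 2510 nM
Compound 3, `COc1ccc2oc(=O)c(-c3ccc(Cl)nn3)cc2c1`: 8800 nM

All three numbers come from an assay on cells for inhibition of Amine oxidase [flavin-containing] B (Homo sapiens), read by fluorescence and Amplex Red, with a stated time of 15 min; on this read-out lower numbers stand for stronger inhibition and higher numbers for weaker inhibition. Compound 1 and compound 2 are built from the same atoms joined differently; the difference between the two cores is not broken down here. Compound 2 gives the lowest of the three numbers, and both its steps to the others are beyond the scatter, so within this set it is the most potent compound.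

Compound 1 and compound 3 are related by one change, (methoxy in place of methyl on an aromatic carbon). The step it made is a 1.5-fold lower number from compound 1 to compound 3 (0.19 log units; within the scatter). Among the measured compounds shown here, one change at a time, this is the only pair in the set that shows the effect of this substitution, and it falls within the scatter, so the data do not show whether methoxy in place of methyl has any real effect on this read-out.

Compound 4, `COc1ccc2cc(-c3ccc(Cl)nn3)c(=O)oc2c1`, is not yet measured. It stands to compound 2 as compound 3 stands to compound 1: the change is methoxy in place of methyl on an aromatic carbon, and since the two place descriptions agree word for word, it is the same change as before. The expectation for compound 4 is therefore taken from that earlier step, a 1.5-fold lower number from compound 1 to compound 3 (0.19 log units; within the scatter), applied to compound 2 and its value 2510 nM. For the measured compounds named here, the step from compound 2 to compound 4 is expected to be a 1.5-fold lower number from compound 2 to compound 4 (0.17 log units; within the scatter), resting on the single measured instance of this change in compound 1 and compound 3. Going by the values given here, compound 4 is thus estimated to give 1700 nM in this assay, with a range from 700 nM to 4000 nM, the width reflecting that the only precedent lies within the scatter.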

Compound 4, half-maximal inhibitory concentration: 19200 nM
Compound 4: the middle estimate sits 11-fold (1.05 log units) below what was measured, and the stated range ends below it.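

In this assay, methoxy in place of methyl on an aromatic carbon gives a 7.6-fold higher number from compound 2 to compound 4 (0.88 log units; beyond the scatter) and so clearly weakens inhibition on the core of compound 2, whereas no real effect can be read on the core of compound 1. The change therefore does not carry over from one core to the other in this series, as the two measured instances differ: the same change on two cores in this assay, a 1.5-fold lower number (0.19 log units; within the scatter) from compound 1 to compound 3 and a 7.6-fold higher number (0.88 log units; beyond the scatter) from compound 2 to compound 4, 12-fold (1.07 log units) apart, beyond the scatter of two such steps.
This shows that, across these four compounds, the result of the change depends on the core that carries it, but with a single pair per core it does not show why the cores differ or whether the same dependence would hold for any other substituent.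

Open, going by these compounds, is how the core of compound 2 responds to other groups on the same aromatic carbon, such as a hydrogen, a fluorine, an ethyl group or a hydroxyl group, which would show whether methyl is specifically favoured there or methoxy specifically disfavoured. Also open, on these data alone, is the role of the chlorine shared by all four compounds, since the set does not show how either core responds when an amine or a methoxy group stands in its place.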